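Pyrazole ureas: chloro for trifluoromethyl, and the methoxy core

The source may report more compounds than this note shows. Statements on the series, on what has been measured and on what is new or still open speak of the compounds shown alone.

Measured compounds:
compound 1 `O=C(Nc1cccc(-n2cc(-c3ccncc3)c(-c3cc(O)cc(Cl)c3)n2)c1)Nc1ccc(Cl)c(C(F)(F)F)c1` — 14.3%
compound 2 `O=C(Nc1cccc(-n2cc(-c3ccncc3)c(-c3cc(O)cc(Cl)c3)n2)c1)Nc1ccc(Cl)c(Cl)c1` — -50.5%
compound 3 `COc1cc(Cl)cc(-c2nn(-c3cccc(NC(=O)Nc4ccc(Cl)c(C(F)(F)F)c4)c3)cc2-c2ccncc2)c1` — -7.48%

In a functional assay on SF-295 cells (Homo sapiens) for inhibition, read by sulforhodamine B assay, with a stated time of 48 h, tested at 10 uM (on this read-out higher numbers stand for a weaker effect at the one concentration tested and lower numbers for a stronger effect), compound 1 gives 14.3%, compound 2 gives -50.5% and compound 3 gives -7.48%. The change chloro in place of trifluoromethyl on an aromatic carbon produced a number 64.8 percentage points lower from compound 1 to compound 2 (beyond the scatter). The cores of compound 1 and compound 3 differ by methyl in place of hydrogen on an oxygen on an aromatic ring, which produced a number 21.8 percentage points lower from compound 1 to compound 3 (beyond the scatter).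

Compound 4 `COc1cc(Cl)cc(-c2nn(-c3cccc(NC(=O)Nc4ccc(Cl)c(Cl)c4)c3)cc2-c2ccncc2)c1` is not yet measured. It differs from compound 3 by chloro in place of trifluoromethyl on an aromatic carbon, the same change as from compound 1 to compound 2, with the place described in the same words. On the strength of the step of a number 64.8 percentage points lower from compound 1 to compound 2 (beyond the scatter), a step of similar size and direction is expected, namely a number 52.5 percentage points lower from compound 3 to compound 4 (beyond the scatter), though it rests on a single precedent. For compound 4 the estimate is -60%, expected to lie between -95% and -20%.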

Compound 4, a percentage reported as activity, at one concentration (the size of the read-out at that concentration, not a potency): -2.42%
The estimate for compound 4 lay 57.6 percentage points below the measured number, outside the stated range (above it).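

In this assay, chloro in place of trifluoromethyl does not carry over from the core of compound 1 to the core of compound 3, where the step is a number 5.1 percentage points higher from compound 3 to compound 4 (within the scatter): the same change on two cores in this assay, a number 64.8 percentage points lower (beyond the scatter) from compound 1 to compound 2 and a number 5.1 percentage points higher (within the scatter) from compound 3 to compound 4, 69.9 percentage points apart, beyond the scatter of two such steps

Methyl in place of hydrogen on the oxygen also depends on the partner group, with 3,4-dichlorophenyl on the urea giving a number 48.1 percentage points higher from compound 2 to compound 4 (beyond the scatter): the same change on two cores in this assay, a number 21.8 percentage points lower (beyond the scatter) from compound 1 to compound 3 and a number 48.1 percentage points higher (beyond the scatter) from compound 2 to compound 4, 69.9 percentage points apart, beyond the scatter of two such steps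

Each step rests on a single pair of compounds, so the set shows that the two changes do not act independently here, but not why, nor how either would behave on another core.

Going by these compounds, whether the low number of compound 2 is specific to the pairing of the free hydroxyl with 3,4-dichlorophenyl remains open. Also open, on these data alone, are a nitrile or a methyl in place of trifluoromethyl, and an amine in place of the hydroxyl.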